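A few compounds are considered here, and "the series" means these few. Any claim that something is new, unique, unknown or untested is made for them only; others in the source may bear on it.

Measured so far:
compound 1, `Nc1sc(Br)c(-c2cccc(C(F)(F)F)c2)c1C(=O)c1ccccc1`: 47.5%
compound 2, `Nc1scc(-c2cccc(C(F)(F)F)c2)c1C(=O)c1ccccc1`: 61.1%
compound 3, `Nc1sc(-c2ccc(Cl)cc2)c(-c2cccc(C(F)(F)F)c2)c1C(=O)c1ccccc1`: 59.1%

In an assay on CHO-K1 cells for displacement of a labelled ligand from adenosine receptor A1 (Homo sapiens), tested at 10 uM (on this read-out lower numbers stand for less inhibition and higher numbers for more inhibition at the one concentration tested (going by the name of the read-out)), compound 3 stands second highest of the three numbers. Its nearest neighbour is compound 2, and the gap a number 2 percentage points lower from compound 2 to compound 3 (within the scatter) lies within the scatter. Compound 1 stands furthest away, and the step of a number 11.6 percentage points higher from compound 1 to compound 3 (beyond the scatter) lies beyond it. Compound 4, `COc1ccc(-c2sc(N)c(C(=O)c3ccccc3)c2-c2cccc(C(F)(F)F)c2)cc1`, has not yet been measured. It differs from compound 3 in one place: methoxy in place of chloro on an aromatic carbon. Going by the values given here, none of the measured steps alters a substituent on the 4-chlorophenyl itself. The step of a number 2 percentage points lower from compound 2 to compound 3 (within the scatter) shows that 4-chlorophenyl in place of hydrogen left the number within the scatter of compound 2, while a number 11.6 percentage points higher from compound 1 to compound 3 (beyond the scatter) and a number 13.6 percentage points higher from compound 1 to compound 2 (beyond the scatter) concern bromo. Among the compounds with values here, no measured step bears directly on methoxy in place of chloro. The expectation for compound 4 in this assay is therefore a step of a number 1.1 percentage points lower from compound 3 to compound 4 (within the scatter) that stays within the scatter. Compound 4 is estimated at 58%, with a range from 42% to 74%.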

Compound 4, a percentage reported as inhibition, at one concentration (the size of the read-out at that concentration, not a potency): 65.2%
Compound 4: the middle estimate sits 7.2 percentage points below what was measured; measured number inside the range.
By their numbers in this assay, from the lowest: compound 1; then compounds 3, 2 and 4 (each within the scatter of the next).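

In this assay, the first change made on the phenyl group itself, from 4-chlorophenyl to 4-methoxyphenyl, gives a number 6.1 percentage points higher from compound 3 to compound 4 (within the scatter), so exchanging chloro for methoxy, which adds a hydrogen-bond acceptor, does not separate the two compounds. A second aryl group at the thiophene-bearing position of the shared core now reads the same way as the first, with a number 4.1 percentage points higher from compound 2 to compound 4 (within the scatter), so neither 4-chlorophenyl nor 4-methoxyphenyl stands apart from hydrogen there. The step of a number 17.7 percentage points higher from compound 1 to compound 4 (beyond the scatter) adds a third compound whose separation from the bromo compound lies beyond the scatter, leaving compound 1 alone at the low end.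

Nothing available explains these numbers. On these data alone, whether an amine, a carboxylic acid or a longer chain such as ethoxy in the place of methoxy would also stay within the scatter of compound 3 remains open.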